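Swapping the aryl group on the styryl carbon of a thioether chalcone

This account rests on a few compounds, and the source may have more. Where it says the series, first, only, none or still open, it means among the compounds named here.

Compound 1: `COc1ccccc1/C=C(/SCc1ccc(F)cc1)C(=O)c1ccc(Cl)cc1` — 10000 nM
Compound 2: `COc1ccccc1/C=C(/Sc1ccc(C)cc1)C(=O)c1ccc(Cl)cc1` — 25000 nM
Compound 3: `COc1ccccc1/C=C(/Sc1ccc(Br)cc1)C(=O)c1ccc(Cl)cc1` — 10000 nM

Three compounds were tested in a functional assay on DU-145 cells (Homo sapiens) for inhibition, read by trypan blue exclusion, with a stated time of 96 h; on this read-out lower numbers stand for stronger inhibition of growth and higher numbers for weaker inhibition of growth. Compound 1 and compound 3 stand level at the digits recorded, together the lowest of the three numbers, and their step is within the scatter: no change at the digits printed from compound 1 to compound 3 (within the scatter). Compound 2 is the furthest from compound 1, with a 2.5-fold higher number from compound 1 to compound 2 (0.40 log units; beyond the scatter), a modest step beyond the scatter. Between compound 2 and compound 3 the change is a 2.5-fold lower number from compound 2 to compound 3 (0.40 log units; beyond the scatter).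

Compound 4 is `O=C(/C(=C\c1ccc(O)cc1)SCc1ccc(F)cc1)c1ccc(Cl)cc1`. It differs from compound 1 at a new place: 4-hydroxyphenyl in place of 2-methoxyphenyl on a double-bonded chain carbon bound to a double-bonded chain carbon Where the measured steps all vary the group on the sulfur, this change leaves the sulfur side untouched and instead exchanges the aryl group on a double-bonded chain carbon bound to a double-bonded chain carbon, with a 2-methoxyphenyl leaving and a 4-hydroxyphenyl entering. None of the three measured steps bears on this position, so nothing here shows how large a shift to expect, or in which direction. In this assay compound 4 is therefore estimated near the number of compound 1, no change at the digits printed from compound 1 to compound 4 (within the scatter), with a wide range: 10000 nM, between 2500 nM and 40000 nM.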

Compound 4, concentration for 50% growth inhibition: 25000 nM
Compound 4: the middle estimate sits 2.5-fold (0.40 log units) below what was measured, within the range that was stated.
By their numbers in this assay, from the lowest: compounds 1 and 3 (each within the scatter of the next); then compounds 2 and 4 (each within the scatter of the next).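

The aryl group on a double-bonded chain carbon bound to a double-bonded chain carbon is not a silent place in this assay: with the 4-fluorobenzyl group on the sulfur kept the same, 4-hydroxyphenyl in place of 2-methoxyphenyl gives a 2.5-fold higher number from compound 1 to compound 4 (0.40 log units; beyond the scatter). Going by these compounds alone, the earlier steps all varied the group on the sulfur, so this is the first sign that the number also moves with a change on the other side of the shared core, and here it moves toward weaker inhibition of growth. No measurement shown accounts for this step.

The swap alters both the group on the ring and its printed ring number, and the compounds shown do not separate the two; a 4-methoxyphenyl or a 2-hydroxyphenyl at this place would tell them apart, and a 4-aminophenyl would show whether a nitrogen group reads like the 4-hydroxyphenyl. As far as these compounds go, it also remains open whether the same exchange gives a step of this size when the sulfur carries 4-bromophenyl or 4-methylphenyl instead of 4-fluorobenzyl.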